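A few compounds are considered here, and "the series" means these few. Any claim that something is new, unique, unknown or untested is made for them only; others in the source may bear on it.

Measured compounds in a functional assay on the whole organism for inhibition, with Rattus norvegicus as the target, read by paw edema, at a dose of 100 mg/kg by the oral route; on this read-out higher numbers stand for more inhibition at the one dose given (going by the name of the read-out) and lower numbers for less inhibition:
compound 1 `CNC(=O)c1c(O)c2cccnc2n(-c2ccccc2)c1=O`, which gives 9.6% in this assay;
compound 2 `O=C(Nc1ccc([N+](=O)[O-])cc1)c1c(O)c2cccnc2n(-c2ccccc2)c1=O`, which gives -7.6%;
compound 3 `COc1ccccc1NC(=O)c1c(O)c2cccnc2n(-c2ccccc2)c1=O`, which gives 8.1%.

Compound 3 stands second highest of the three numbers. Its gap to compound 1 is within the scatter, as a number 1.5 percentage points lower from compound 1 to compound 3 (within the scatter) shows, while its gap to compound 2 is beyond it: a number 15.7 percentage points higher from compound 2 to compound 3 (beyond the scatter).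

The next compound, compound 4 `O=C(Nc1nccs1)c1c(O)c2cccnc2n(-c2ccccc2)c1=O`, differs from compound 3 in one place: 1,3-thiazol-2-yl in place of 2-methoxyphenyl on an amide-type nitrogen.

All three measured steps vary the group on the same amide-type nitrogen. Methyl to 2-methoxyphenyl moved little, a number 1.5 percentage points lower from compound 1 to compound 3 (within the scatter); methyl to 4-nitrophenyl moved more, a number 17.2 percentage points lower from compound 1 to compound 2 (beyond the scatter), and only in that case did the step pass the scatter. Within the data shown here, no measured step covers a thiazolyl group, so the expectation for this assay is a step near the scatter, slightly downward if anything.

Compound 4 is therefore expected to give about 5%, in the range -12% to 20%, an expected step of a number 3.1 percentage points lower from compound 3 to compound 4 (within the scatter).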

Compound 4, a percentage reported as inhibition, in the whole organism at one dose (the size of the read-out at that dose, not a potency): 4.6%
Beside the measured number, compound 4's estimate is 0.4 percentage points above it; measured number inside the range.
By their numbers in this assay, from the lowest: compound 2; then compounds 4, 3 and 1 (each within the scatter of the next).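

With 1,3-thiazol-2-yl on the amide-type nitrogen, a five-membered aromatic ring is now read in this assay and does not separate from the earlier groups methyl and 2-methoxyphenyl: the steps are a number 3.5 percentage points lower from compound 3 to compound 4 (within the scatter) and a number 5 percentage points lower from compound 1 to compound 4 (within the scatter) while only a number 12.2 percentage points higher from compound 2 to compound 4 (beyond the scatter) passes the scatter. Among these four amides, compound 2 alone stands apart, and the other three cannot be ordered on this read-out. No evidence here bears on why this change leaves the number where it is.
On these data alone, whether an amine, a carboxylic acid or a longer chain on the amide-type nitrogen would separate from methyl stays open.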